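The compounds below may be only part of what the source reports. "The series", "measured", "known", "first", "only" and "open" are said of these compounds alone.

Compound 2 `CCCn1nc(C(=O)N[C@H]2COc3ccccc3N(C)C2=S)nc1Cc1ccccc1` was tested in a toxicity assay on HT-29 cells (Homo sapiens) for cytotoxicity; on this read-out higher numbers stand for lower toxicity in this test and lower numbers for higher toxicity in this test. In this assay compound 2 gives only a limit, > 100000 nM. Compound 1 `CN1C(=S)[C@@H](NC(=O)c2nc(Cc3ccccc3)n(C)n2)COc2ccccc21` likewise gives a limit in this assay, > 100000 nM. Compound 3 `CN1C(=S)[C@@H](NC(=O)c2nc(Cc3ccccc3)n(CCC(F)(F)F)n2)COc2ccccc21` also gives a limit in this assay, > 100000 nM. Each of the three values sits at the limit of > 100000 nM in this assay, at which 3 of the 3 values shown sit, so the numbers place compound 2 no differently from the others. Compound 4 `CN1C(=S)[C@@H](NC(=O)c2nc(Cc3ccccc3)n(CCCCC#N)n2)COc2ccccc21` differs from compound 2 by cyanomethyl in place of hydrogen on a saturated chain carbon, three bonds along the chain from an aromatic nitrogen. The measured steps that bear on this change are a step that the two limits leave unreadable from compound 1 to compound 2 and a step that the two limits leave unreadable from compound 2 to compound 3, together with a step that the two limits leave unreadable from compound 1 to compound 3, and none of them yields a readable size. No step beyond the scatter is therefore expected in this assay. Compound 4 is estimated to give 100000 nM, expected between 30000 nM and 300000 nM. The expected step is a number no higher from compound 2 to compound 4 (the limit leaves the size open).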

Compound 4, half-maximal cytotoxic concentration: > 100000 nM
Compound 4 ended at the assay's limit; the forecaster's own chance of this, stated with the estimate: 85%; the middle value sits exactly at the limit.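

In this assay, going by these compounds alone, no step linking compound 4 with compound 1, compound 2 or compound 3 can be read, because all four values are limits: the limit of > 100000 nM in this assay, at which 4 of the 4 values shown sit. The compounds shown leave open how these side chains truly rank in this test.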